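The source may hold more compounds than are shown below. What is called first, only, known or untested is meant among the compounds shown, and "the series" means these compounds.

Compound 1, `COc1cc(-c2cc(/C=C/C(=O)c3ccc(N)cc3)[nH]n2)cc(OC)c1OC`, is the starting point of this comparison. In a functional assay on 786-0 cells (Homo sapiens) for inhibition, read by sulforhodamine B assay, with a stated time of 48 h (on this read-out lower numbers stand for higher toxicity in this test and higher numbers for lower toxicity in this test), compound 1 gives 27600 nM, the higher of the two numbers available here, while compound 2, `COc1ccc(-c2cc(/C=C/C(=O)c3ccc(OC)c(OC)c3)[nH]n2)cc1`, gives 5960 nM in this assay. Compound 3, `COc1cc(-c2cc(/C=C/C(=O)c3ccc(Cl)c(Cl)c3)[nH]n2)cc(OC)c1OC`, yields only a limit in this assay, > 100000 nM. That limit is the limit of > 100000 nM in this assay, at which 1 of the 3 values shown sits. Among the compounds with values here, the single measured step, an at least 3.6-fold higher number from compound 1 to compound 3 (0.55 log units; beyond the scatter), alters the group attached to the carbonyl carbon, not the ring on the other side of the shared core.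

Compound 4, `COc1ccc(-c2cc(/C=C/C(=O)c3ccc(N)cc3)[nH]n2)cc1OC`, differs from compound 1 by hydrogen in place of methoxy on an aromatic carbon. Within the data shown here, no measured step touches that part of the molecule, so the one step that exists gives little guidance. The change removes a methoxy group from a position untouched by any measured step. The expectation in this assay is a step small enough to stay within the scatter, with no firm direction. The value for compound 4 is therefore estimated at 20000 nM, within 6000 nM to 70000 nM. That estimate amounts to an expected step of a 1.4-fold lower number from compound 1 to compound 4 (0.14 log units; within the scatter).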

Compound 4, concentration lethal to 50% of the cells: 10800 nM
Compound 4: the middle estimate sits 1.9-fold (0.27 log units) above what was measured; the measured number falls inside the stated range.
By their numbers in this assay, from the lowest: compounds 2 and 4 (each within the scatter of the next); then compound 1. At a limit, above all of these: compound 3.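

Within the data shown here, this change reaches a part of the molecule that no earlier step touched: the earlier step altered the group on the carbonyl carbon, whereas this one alters the ring on the other side of the shared core. In this assay, hydrogen in place of methoxy gives a 2.6-fold lower number from compound 1 to compound 4 (0.41 log units; beyond the scatter), so this methoxy position affects the read-out, and losing the group here brings higher toxicity in this test. Nothing available explains why this swap has that effect.

On these data alone, one swap at one position gives only a single direction, so it remains open how an amine, a fluorine or a longer chain such as ethoxy would compare in the same place. As far as these compounds go, it is also open whether removing this methoxy has a similar effect when 3,4-dichlorophenyl stands on the carbonyl carbon.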